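Swapping a Urea for a Benzylamine on a Shared Core

A few compounds are considered here, and "the series" means these few. Any claim that something is new, unique, unknown or untested is made for them only; others in the source may bear on it.

Of the compounds shown here, two built on the same core have been measured in an assay on CHO cells for displacement of a labelled ligand from 5-hydroxytryptamine receptor 1D (Homo sapiens); a lower number here means a stronger inhibitor, a higher number a weaker inhibitor. Compound 1 `CN(CC1CCN(CCCc2c[nH]c3ccc(-n4cnnc4)cc23)CC1)C(=O)Nc1ccccc1` is the weaker of the two in this assay, giving 5.9 nM, the highest of the two numbers recorded. Compound 2 `C[C@@H](NCC1CCN(CCCc2c[nH]c3ccc(-n4cnnc4)cc23)CC1)c1ccccc1` is the closest relative of compound 1. In this assay compound 2 gives 1.4 nM, a step of a 4.2-fold lower number from compound 1 to compound 2 (0.62 log units; beyond the scatter).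

The compound still to be measured is compound 3 `c1ccc(CNCC2CCN(CCCc3c[nH]c4ccc(-n5cnnc5)cc34)CC2)cc1`. Compared with compound 1 the change is benzylamino in place of methyl(phenylcarbamoyl)amino on a saturated chain carbon bound to a saturated ring carbon. Going by the values given here, the only measured step that bears on this change is the one from compound 1 to compound 2, since the group entering there, (1-phenylethyl)amino, is close to the benzylamino group entering here, and it produced a 4.2-fold lower number from compound 1 to compound 2 (0.62 log units; beyond the scatter). A step of a similar size and in the same direction is therefore expected for compound 3, and the number is estimated at a 3.0-fold lower number from compound 1 to compound 3 (0.47 log units; beyond the scatter) relative to compound 1. In this assay compound 3 is expected to give about 2 nM, with a plausible range from 0.7 nM to 6 nM.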

Compound 3, half-maximal inhibitory concentration: 1.6 nM
Compound 3: middle estimate off by 1.3-fold (0.10 log units), on the high side; the measured number falls inside the stated range.
By their numbers in this assay, from the lowest: compounds 2 and 3 (each within the scatter of the next); then compound 1.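

In this assay, replacing methyl(phenylcarbamoyl)amino with benzylamino gives a 3.7-fold lower number from compound 1 to compound 3 (0.57 log units; beyond the scatter), so a simple benzylamino group is enough to move the number beyond the scatter, without the extra methyl carried by compound 2. That methyl, on a saturated chain carbon bound to an amine nitrogen and an aromatic carbon, can be removed with little consequence here: the change gives a 1.1-fold higher number from compound 2 to compound 3 (0.06 log units; within the scatter), so compounds 2 and 3 cannot be told apart in this assay. No supporting evidence is available to explain why the two amines give lower numbers than the urea of compound 1.

The compounds shown leave open how far this tolerance extends, for example whether a longer chain, as in 2-phenylethylamino, or a fluorine on the phenyl ring would keep the number in the same range. They also leave open which part of the urea matters, since a urea without its nitrogen methyl or an amide in its place would be needed to separate the contribution of the carbonyl from that of the methyl.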